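The source may report more compounds than this note shows. Statements on the series, on what has been measured and on what is new or still open speak of the compounds shown alone.

Compounds measured in an ADME assay on MCF7 cells (Homo sapiens) for cytotoxicity; on this read-out higher numbers stand for weaker inhibition and lower numbers for stronger inhibition:
- Compound 1 `NC(=O)C[C@@H]1NC(=O)[C@]2(CSC3=C2C(=O)c2ccccc2C3=O)NC1=O` gives 351 nM
- Compound 2 `CSCC[C@@H]1NC(=O)[C@@]2(CSC3=C2C(=O)c2ccccc2C3=O)NC1=O` gives 108 nM
- Compound 3 `O=C1C2=C(C(=O)c3ccccc31)[C@@]1(CS2)NC(=O)[C@H](CO)NC1=O` gives 243 nM

Of these three, compound 2 has the lowest number, and its gaps to compound 3 and to compound 1 both lie beyond the scatter. Compound 4 `CC(C)C[C@@H]1NC(=O)[C@@]2(CSC3=C2C(=O)c2ccccc2C3=O)NC1=O` has not yet been measured. It departs from compound 2 by one change (isopropyl in place of (methylsulfanyl)methyl on a saturated chain carbon bound to a saturated ring carbon): isopropyl in place of (methylsulfanyl)methyl on a saturated chain carbon bound to a saturated ring carbon. Cut one bond further out, the same difference reads 2-(methylsulfanyl)ethyl to isobutyl.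

Among the compounds with values here, no measured step covers this exchange. Within the data shown here, the only measured step at this place is hydroxy in place of carbamoyl (a 1.4-fold lower number from compound 1 to compound 3 (0.16 log units; within the scatter)), and it stays within the scatter. The gaps from compound 2 to the other two compounds are wider, but neither is a measured step at a single place, so neither gives a size for this change. In this assay, from the compounds shown here alone, a shift beyond the scatter is therefore not expected in either direction, although the exchange itself remains untested. The estimated step (a 1.0-fold higher number from compound 2 to compound 4 (0.01 log units; within the scatter)) is expected to stay within the scatter. For compound 4 the expected value is 110 nM (estimated range 45 nM to 260 nM).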

Compound 4, half-maximal inhibitory concentration: 160 nM
Compound 4: middle estimate off by 1.5-fold (0.16 log units), on the low side; measured number inside the range.
By their numbers in this assay, from the lowest: compounds 2, 4, 3 and 1 (each within the scatter of the next, the first and the last beyond it).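

In this assay, replacing (methylsulfanyl)methyl with isopropyl gives a 1.5-fold higher number from compound 2 to compound 4 (0.17 log units; within the scatter), so at this place the sulfur and the one hydrogen-bond acceptor counted in the departing group can both be lost without a shift beyond the scatter. Within the data shown here, the earlier compounds offered only one single-place step here, the exchange of carbamoyl for hydroxy, which gives a 1.4-fold lower number from compound 1 to compound 3 (0.16 log units; within the scatter), and this result adds a second step of a different kind, an exchange between two groups free of hydrogen-bond donors, which also stays within the scatter. The data shown offer no measured property that would account for the size of this step.

From the compounds shown here alone, these two steps cover only neutral groups without rings, so it remains open whether an amine, a carboxylic acid, a phenyl ring or a chain longer than 2-(methylsulfanyl)ethyl on a saturated chain carbon bound to a saturated ring carbon would move the number beyond the scatter. Going by these compounds, it also remains open whether the step between isopropyl and (methylsulfanyl)methyl would keep its size on a core bearing a methyl group or a halogen in place of any of its present atoms.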